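Working notes: from compound 2 to compound 3

The source may hold more compounds than are shown below. What is called first, only, known or untested is meant among the compounds shown, and "the series" means these compounds.

Compound 2 `CC(C)C(c1nnc[nH]1)c1ccc(-c2ccc3cccc(F)c3c2)[nH]c1=O` stands lowest of the two numbers in an ADME assay on microsomes from liver (Homo sapiens) for metabolic stability; a lower number here means that the compound disappears faster, a higher number that the compound lasts longer; in that assay compound 2 gives 0.905 h. Going by the values given here, the nearest, compound 1 `CCn1ncc2c(F)cc(-c3ccc(C(CC)(CC)c4nncn4C)c(=O)[nH]3)cc21`, gives 2.67 h in this assay, a gap beyond the scatter; no single-change step connects the two, so only the two values can be read. Compound 3 `CC(C)C(CC(N)=O)c1ccc(-c2ccc3cccc(F)c3c2)[nH]c1=O` differs from compound 2 by carbamoylmethyl in place of 4H-1,2,4-triazol-3-yl on a saturated chain carbon bound to an aromatic carbon and a saturated chain carbon. Among the compounds with values here, no measured step bears on this change. The step from compound 2 to compound 3 is expected to be small, with no direction supported, at a 1.1-fold higher number from compound 2 to compound 3 (0.04 log units; within the scatter). Compound 3 is estimated at 1 h, within 0.45 h to 2.2 h.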

Compound 3, half-life: < 0.0667 h
Compound 3: only a limit was reported (the forecaster's own chance of this, stated with the estimate: 5%); middle value at least 14-fold (1.17 log units) away from the limit.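

On a saturated chain carbon bound to an aromatic carbon and a saturated chain carbon, the position is far from neutral in this assay: carbamoylmethyl in place of 4H-1,2,4-triazol-3-yl gives an at least 13-fold lower number from compound 2 to compound 3 (1.13 log units; beyond the scatter). Compound 3 gives < 0.0667 h, which is a limit of the assay and not a number. The full size of the step therefore stays unresolved, and the reading rests on this limit: the limit of < 0.0667 h in this assay, at which 1 of the 3 values shown sits.

The compounds shown leave open how a carboxylic acid or an amine at this place would read. As far as these compounds go, whether the same change gives a similar step on the core of compound 1 also remains open.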